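Methoxy Enters the Benzyloxy Ring of Compound 1

This account rests on a few compounds, and the source may have more. Where it says the series, first, only, none or still open, it means among the compounds named here.

Measured in a functional assay on MCF7 cells (Homo sapiens) for antiproliferative activity, read by sulforhodamine B assay, with a stated time of 72 h; on this read-out lower numbers stand for stronger inhibition and higher numbers for weaker inhibition:
- compound 1 `FC(F)(F)c1ccc(CN2CCN(Cc3cc(-c4ccc(OCc5ccccc5)cc4)on3)CC2)cc1` gives 2900 nM
- compound 2 `Cc1cccc(COc2ccc(-c3cc(CN4CCN(Cc5ccc(C(F)(F)F)cc5)CC4)no3)cc2)c1` gives 4000 nM
- compound 3 `Fc1ccccc1COc1ccc(-c2cc(CN3CCN(Cc4ccc(C(F)(F)F)cc4)CC3)no2)cc1` gives 3000 nM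

Compound 1 has the lowest of the three numbers, yet its steps to the others, a 1.0-fold higher number from compound 1 to compound 3 (0.01 log units; within the scatter) and a 1.4-fold higher number from compound 1 to compound 2 (0.14 log units; within the scatter), both stay within the scatter, so the three compounds cannot be ranked. Compound 4 `COc1ccccc1COc1ccc(-c2cc(CN3CCN(Cc4ccc(C(F)(F)F)cc4)CC3)no2)cc1` differs from compound 1 by methoxy in place of hydrogen on an aromatic carbon. The two measured steps that bear on this, each adding a small substituent to the benzyloxy ring, stayed within the scatter, so for compound 4 no step beyond the scatter is expected in this assay, at most a slight drift to a higher number, a 1.2-fold higher number from compound 1 to compound 4 (0.08 log units; within the scatter). Compound 4 is therefore estimated at 3500 nM, within 1700 nM to 7500 nM.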

Compound 4, half-maximal inhibitory concentration: 300 nM
The estimate for compound 4 lay 12-fold (1.07 log units) above the measured number; measured number outside the range, below it.
By their numbers in this assay, from the lowest: compound 4; then compounds 1, 3 and 2 (each within the scatter of the next).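

In this assay, among these compounds, the benzyloxy ring proves sensitive to what it carries: methoxy in place of hydrogen gives the first step here beyond the scatter (a 9.7-fold lower number from compound 1 to compound 4 (0.99 log units; beyond the scatter)). The identity of the group matters, as methoxy in place of fluoro gives a step of similar size (a 10-fold lower number from compound 3 to compound 4 (1.00 log units; beyond the scatter)), and 2-methoxyphenyl in place of 3-methylphenyl gives the largest (a 13-fold lower number from compound 2 to compound 4 (1.12 log units; beyond the scatter)). Nothing available here explains this drop in the number. Going by these compounds, whether a hydroxy or an ethoxy group on this ring would give a similar drop remains open.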